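The source may hold more compounds than are shown below. What is called first, only, known or untested is meant among the compounds shown, and "the series" means these compounds.

Measured in an ADME assay on cells (Homo sapiens) for cytotoxicity, read by polymerase chain reaction, with a stated time of 3 days; a higher number here means that more compound is tolerated, a lower number that less compound is tolerated:
compound 1, `Cc1nc(NCC2CCC2)nc(N[C@@H]2C[C@H](CO)[C@@H](O)[C@H]2O)c1-c1nc2ccccc2s1`: in this assay compound 1 gives > 25000 nM, which is a limit of the assay.
compound 2, `COCCNc1nc(C)c(-c2nc3ccccc3s2)c(N[C@@H]2C[C@H](CO)[C@@H](O)[C@H]2O)n1`: in this assay compound 2 gives 21000 nM.
compound 3, `Cc1nc(NCCOC(C)C)nc(N[C@@H]2C[C@H](CO)[C@@H](O)[C@H]2O)c1-c1nc2ccccc2s1`: in this assay compound 3 gives 8000 nM.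

Compound 3 holds the lowest of the two numbers; the nearest is compound 2, separated by a 2.6-fold lower number from compound 2 to compound 3 (0.42 log units; beyond the scatter). Compound 1 sits at the limit (the limit of > 25000 nM in this assay, at which 1 of the 3 values shown sits).

Compound 4, `Cc1nc(NCCC(F)(F)F)nc(N[C@@H]2C[C@H](CO)[C@@H](O)[C@H]2O)c1-c1nc2ccccc2s1`, differs from compound 3 by trifluoromethyl in place of isopropoxy on a saturated chain carbon, two bonds along the chain from a nitrogen on an aromatic ring. Going by the values given here, the steps that bear on this chain are an at least 3.1-fold lower number from compound 1 to compound 3 (0.49 log units; beyond the scatter) and a 2.6-fold lower number from compound 2 to compound 3 (0.42 log units; beyond the scatter), both ending at compound 3, both beyond the scatter. Neither introduces a trifluoromethyl at this place, so no direction is secured; a small step back toward the higher numbers of compound 1 and compound 2 seems as likely as none, and the expected step is a 1.4-fold higher number from compound 3 to compound 4 (0.14 log units; within the scatter). The estimate for compound 4 is 11000 nM, expected between 4500 nM and 25000 nM.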

Compound 4, half-maximal cytotoxic concentration: 9000 nM
The estimate for compound 4 lay 1.2-fold (0.09 log units) above the measured number, within the range that was stated.
By their numbers in this assay, from the lowest: compounds 3 and 4 (each within the scatter of the next); then compound 2. At a limit, above all of these: compound 1.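

In this assay, trifluoromethyl and isopropoxy on this saturated chain carbon, two bonds along the chain from a nitrogen on an aromatic ring, cannot be told apart (a 1.1-fold higher number from compound 3 to compound 4 (0.05 log units; within the scatter)). Compound 4 carries no oxygen in this chain yet stands apart from the methoxy compound (a 2.3-fold lower number from compound 2 to compound 4 (0.37 log units; beyond the scatter)), so a chain oxygen is not required for this lower level. The step from cyclobutyl (an at least 2.7-fold lower number from compound 1 to compound 4 (0.44 log units; beyond the scatter)) is only a floor, since compound 1 gives a limit and not a number: the limit of > 25000 nM in this assay, at which 1 of the 4 values shown sits.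

Going by these compounds, whether an amine, a carboxylic acid or a longer chain at this place would shift the number stays open.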